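Shifting the Hydroxymethyl Group Around the Distal Ring

This account rests on a few compounds, and the source may have more. Where it says the series, first, only, none or still open, it means among the compounds named here.

Compound 3 `O=C(O)CC/C=C\CO[C@H]1C(OCc2ccc(-c3ccc(CO)cc3)cc2)CC[C@@H]1N1CCCCCC1` stands second highest of the three numbers in a functional assay on blood for antagonist activity at thromboxane A2 receptor (Homo sapiens) (on this read-out higher numbers stand for weaker binding and lower numbers for tighter binding), giving 3.16 nM. Compound 2 `CC(=O)NCc1ccc(-c2ccc(COC3CC[C@H](N4CCCCCC4)[C@H]3OC/C=C\CCC(=O)O)cc2)cc1` gives 2.51 nM, and compound 1 `O=C(O)CC/C=C\CO[C@H]1C(OCc2ccc(-c3ccccc3)cc2)CC[C@@H]1N1CCCCCC1` gives 12.6 nM. Compound 4 `O=C(O)CC/C=C\CO[C@H]1C(OCc2ccc(-c3ccccc3CO)cc2)CC[C@@H]1N1CCCCCC1` differs from compound 3 by 2-(hydroxymethyl)phenyl in place of 4-(hydroxymethyl)phenyl on an aromatic carbon, the change sitting on an aromatic carbon of a six-membered aromatic ring of carbon only, para to a large group. Within the data shown here, no measured step moves a group around that ring; the related steps only add one there: a 4.0-fold lower number from compound 1 to compound 3 (0.60 log units; beyond the scatter) and a 5.0-fold lower number from compound 1 to compound 2 (0.70 log units; beyond the scatter), while a 1.3-fold higher number from compound 2 to compound 3 (0.10 log units; within the scatter). Because the gain from adding the group was only a 4.0-fold lower number from compound 1 to compound 3 (0.60 log units; beyond the scatter), shifting it is expected to give back part of it, an estimated 2.0-fold higher number from compound 3 to compound 4 (0.30 log units; within the scatter). Compound 4 is therefore expected at 6.3 nM, between 2.5 nM and 16 nM.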

Compound 4, dissociation constant: 3.16 nM
Estimate against measurement, compound 4: 2.0-fold (0.30 log units) above; the measured number falls inside the stated range.
By their numbers in this assay, from the lowest: compounds 2, 3 and 4 (each within the scatter of the next); then compound 1.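

In this assay, 2-(hydroxymethyl)phenyl in place of 4-(hydroxymethyl)phenyl gives no change at the digits printed from compound 3 to compound 4 (within the scatter), so the two placements on this ring cannot be told apart. The gain over the ring without the group persists after the shift, with a 4.0-fold lower number from compound 1 to compound 4 (0.60 log units; beyond the scatter), while against the acetamidomethyl analogue there is a 1.3-fold higher number from compound 2 to compound 4 (0.10 log units; within the scatter). No evidence bears on why the read-out tolerates this shift. The compounds shown leave open whether an amine or a carboxylic acid at this place would behave like hydroxymethyl. They also leave open whether a longer chain ending in hydroxy would do so.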